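The compounds below may be only part of what the source reports. "The series", "measured", "known", "first", "only" and "open" are said of these compounds alone.

In a functional assay on HT-29 cells (Homo sapiens) for antiproliferative activity, read by sulforhodamine B assay, with a stated time of 48 h (on this read-out higher numbers stand for weaker inhibition and lower numbers for stronger inhibition), three compounds with a shared core have been measured. Compound 1 (`CCc1ccccc1NS(=O)(=O)c1ccc(N2CCNC2=O)cc1`) gives 240 nM, compound 2 (`Cc1ccc(NS(=O)(=O)c2ccc(N3CCNC3=O)cc2)cc1`) gives 480 nM, and compound 3 (`O=C1NCCN1c1ccc(S(=O)(=O)Nc2ccccc2)cc1`), which carries phenyl on a sulfonamide nitrogen, gives 280 nM. Compound 3 therefore stands within the scatter of both other compounds, and no order can be drawn among the three.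

The next compound is compound 4 (`O=C1NCCN1c1ccc(S(=O)(=O)Nc2ccc(F)c(F)c2)cc1`), with 3,4-difluorophenyl in place of phenyl on a sulfonamide nitrogen.

For the measured compounds named here, no measured compound carries fluorine, so the available steps bear on this change only indirectly. They do show how little this group has moved the read-out so far. Adding ethyl or methyl to the group gives a 1.2-fold higher number from compound 1 to compound 3 (0.07 log units; within the scatter) and a 1.7-fold lower number from compound 2 to compound 3 (0.23 log units; within the scatter), and the exchange between the two substituted groups gives a 2.0-fold higher number from compound 1 to compound 2 (0.30 log units; within the scatter). On the evidence of these small steps, no change beyond the scatter is expected in this assay, and the data suggest no direction.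

The estimated step is a 1.1-fold higher number from compound 3 to compound 4 (0.03 log units; within the scatter).

For compound 4 the expected value is 300 nM, with an estimated range from 110 nM to 800 nM.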

Compound 4, half-maximal inhibitory concentration: 350 nM
Compound 4: the middle estimate sits 1.2-fold (0.07 log units) below what was measured; low and high end bracket the measured number.
By their numbers in this assay, from the lowest: compounds 1, 3, 4 and 2 (each within the scatter of the next).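

In this assay, for the compounds shown here, 3,4-difluorophenyl in place of phenyl on a sulfonamide nitrogen gives a 1.3-fold higher number from compound 3 to compound 4 (0.10 log units; within the scatter), and this is the only step that brings fluorine onto this group. The same compound, set against the two groups bearing a single alkyl substituent, gives a 1.4-fold lower number from compound 2 to compound 4 (0.14 log units; within the scatter) and a 1.5-fold higher number from compound 1 to compound 4 (0.16 log units; within the scatter), so every step to compound 4 also stays within the scatter. Among these four compounds, this position has now taken two fluorines as well as methyl and ethyl without any printed step leaving the scatter, and no supporting data are available to account for this result.

As far as these compounds go, all four groups on this nitrogen are substituted or unsubstituted phenyl, so it remains open whether a phenyl carrying an amine or a carboxylic acid, or a saturated group such as cyclohexyl or a longer alkyl chain, would move the number beyond the scatter. From the compounds shown here alone, it also remains open whether a change elsewhere on the shared core would shift the read-out further than any change at this nitrogen has so far.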